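Aryl ketone variation in a cytotoxicity series

The source may report more compounds than this note shows. Statements on the series, on what has been measured and on what is new or still open speak of the compounds shown alone.

Measured so far:
compound 1 `C#CCSc1nnc(-c2cc(OC)c(OC)c(OC)c2)n1N1C(=O)c2ccccc2C1=O`: in a functional assay on MKN-45 cells (Homo sapiens) for cytotoxicity, read by MTT assay, with a stated time of 48 h (a lower number here means a stronger inhibitor, a higher number a weaker inhibitor), compound 1 gives > 200000 nM, a limit of the assay and not a number.
compound 2 `COc1cc(-c2nnc(SCC(=O)c3ccc(Cl)cc3)n2N2C(=O)c3ccccc3C2=O)cc(OC)c1OC`: compound 2 gives 26600 nM.
compound 3 `COc1ccc(C(=O)CSc2nnc(-c3cc(OC)c(OC)c(OC)c3)n2N2C(=O)c3ccccc3C2=O)cc1`: compound 3 gives 37200 nM.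

Compound 3 holds the highest of the two numbers shown, with compound 2 nearest and within the scatter of it. Compound 4 `COc1cc(-c2nnc(SCC(=O)c3ccccc3C)n2N2C(=O)c3ccccc3C2=O)cc(OC)c1OC` differs from compound 3 by 2-methylphenyl in place of 4-methoxyphenyl on a carbonyl carbon. Among the measured compounds shown here, the one step that bears on such an aryl substituent swap is a 1.4-fold higher number from compound 2 to compound 3 (0.15 log units; within the scatter), which stayed within the scatter. The larger steps of an at least 7.5-fold lower number from compound 1 to compound 2 (0.87 log units; beyond the scatter) and an at least 5.3-fold lower number from compound 1 to compound 3 (0.73 log units; beyond the scatter) concern the whole aryl ketone and do not separate one aryl group from another. No step beyond the scatter is therefore expected in this assay. Compound 4 is expected near 35000 nM, between 12000 nM and 100000 nM. This implies an expected step of a 1.1-fold lower number from compound 3 to compound 4 (0.03 log units; within the scatter).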

Compound 4, half-maximal inhibitory concentration: > 200000 nM
Compound 4: only a limit was reported; the forecaster's own chance of this, stated with the estimate: 5%; at least 5.7-fold (0.75 log units) between middle value and limit.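

In this assay the aryl group on the carbonyl carbon matters: 2-methylphenyl in place of 4-methoxyphenyl gives an at least 5.3-fold higher number from compound 3 to compound 4 (0.73 log units; beyond the scatter), and in place of 4-chlorophenyl it gives an at least 7.5-fold higher number from compound 2 to compound 4 (0.87 log units; beyond the scatter). An aryl ketone alone therefore does not secure a number short of the limit, and the step from compound 1 to compound 4 cannot be read. The value of compound 4 is a limit of the assay and not a number: the limit of > 200000 nM in this assay, at which 2 of the 4 values shown sit.

Still open, as far as these compounds go, is whether 4-methylphenyl on the same carbonyl carbon would stay with compound 2 and compound 3 or fall with compound 4. From the compounds shown here alone, the effect of an amine or a carboxylic acid on that aryl ring is also open.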